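Adding a Propargyl Group to the Amine of Compound 1

A few compounds are considered here, and "the series" means these few. Any claim that something is new, unique, unknown or untested is made for them only; others in the source may bear on it.

Compounds measured in an assay on Sf9 cells for inhibition of Amine oxidase [flavin-containing] B (Homo sapiens), with stated times of 15 min and 60 min; on this read-out higher numbers stand for weaker inhibition and lower numbers for stronger inhibition:
compound 1, `Cc1cc(OCc2cccc(F)c2)ccc1CN[C@@H](C)C(N)=O`, 69 nM
compound 2, `NC(=O)C1CCN1Cc1ccc(OCc2cccc(F)c2)cc1`, 46 nM
compound 3, `C[C@H](NCc1ccc(OCc2cccc(F)c2)cc1C1CC1)C(N)=O`, 1660 nM

Among these three numbers compound 1 stands second highest. Its nearest neighbour is compound 2, whose value lies within the usual scatter of that of compound 1, so the two cannot be told apart on this read-out. Its furthest neighbour is compound 3: a 24-fold higher number from compound 1 to compound 3 (1.38 log units; beyond the scatter). That large step came from cyclopropyl in place of methyl on an aromatic carbon, a change on the ring and not on the amine.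

The unmeasured compound 4, `C#CCN(Cc1ccc(OCc2cccc(F)c2)cc1C)[C@@H](C)C(N)=O`, differs from compound 1 in one place: propargyl in place of hydrogen on an amine nitrogen. Among the compounds with values here, no measured pair differs at the amine nitrogen, so the one step on record concerns a ring substituent and does not show how this assay responds to a group on that nitrogen. Without such a guide, the number for compound 4 is expected to sit near that of compound 1, and the step is estimated as a 1.2-fold lower number from compound 1 to compound 4 (0.06 log units; within the scatter), which is within the scatter. The estimate for compound 4 is 60 nM, with a range from 12 nM to 300 nM.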

Compound 4, half-maximal inhibitory concentration: 320 nM
The estimate for compound 4 lay 5.3-fold (0.73 log units) below the measured number; the measured number lies above the stated range.
By their numbers in this assay, from the lowest: compounds 2 and 1 (each within the scatter of the next); then compound 4; then compound 3.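

The amine nitrogen of compound 1 is a position where this assay responds to change: in this assay, putting propargyl in place of hydrogen gives a 4.6-fold higher number from compound 1 to compound 4 (0.67 log units; beyond the scatter), a modest step but one beyond the usual scatter of repeated measurements. Inhibition is weakened but not lost, since compound 4 still gives 320 nM, so the nitrogen can carry this group of three carbon atoms and its triple bond at some cost. Nothing available here says why the number rises when the amine hydrogen is replaced.

Within the data shown here, with only one group on this nitrogen, the result cannot separate an effect of any added group from one specific to propargyl, and a simple methyl or ethyl group on the same nitrogen, or a saturated propyl chain with no triple bond, would help to tell these apart. Going by these compounds, it also remains open whether propargyl would bring a similar step on compound 3, which carries cyclopropyl in place of methyl and still has its hydrogen on the amine nitrogen.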